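This account rests on a few compounds, and the source may have more. Where it says the series, first, only, none or still open, it means among the compounds named here.

Working notes on the series built on the shared core of compound 1 `O=C(CCCCCCc1ccccc1)c1nc(Cl)co1`, assessed in an assay on HEK-293T cells for inhibition of diacylglycerol lipase-alpha (Homo sapiens), read by colorimetric assay; a higher number here means a weaker inhibitor, a lower number a stronger inhibitor. In this assay compound 1 gives 2400 nM. Compound 2 `COc1coc(C(=O)CCCCCCc2ccccc2)n1` differs by methoxy in place of chloro on an aromatic carbon. In this assay compound 2 returns > 10000 nM, which is a limit of the assay and not a number. The step of an at least 4.1-fold higher number from compound 1 to compound 2 (0.61 log units; beyond the scatter) places compound 2 at the weak end of the two values shown, with only a limit known for it, as described by the limit of > 10000 nM in this assay, at which 1 of the 2 values shown sits.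

Compound 3 `O=C(CCCCCCc1ccccc1)c1nc(Br)co1` has not yet been measured in this assay. Its change from compound 2 reads (bromo in place of methoxy on an aromatic carbon), a bromo in place of methoxy on an aromatic carbon of a five-membered aromatic ring with one nitrogen and one oxygen. For the measured compounds named here, the only measured step bearing on it is an at least 4.1-fold higher number from compound 1 to compound 2 (0.61 log units; beyond the scatter), in which methoxy replaced a halogen on that same carbon. Restoring a halogen is therefore expected to reverse that step, a decrease beyond the scatter in this assay, back toward where compound 1 sits. Compound 3 is expected to give 2500 nM in this assay, within 800 nM to 8000 nM. The expected step is an at least 4.0-fold lower number from compound 2 to compound 3 (0.60 log units; beyond the scatter).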

Compound 3, half-maximal inhibitory concentration: > 10000 nM
Compound 3: no number, only a limit (the forecaster's own chance of this, stated with the estimate: 12%); middle value at least 4.0-fold (0.60 log units) away from the limit.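

In this assay compound 3 returns > 10000 nM, which is a limit of the assay and not a number. The earlier pair left open whether any halogen on this carbon of the shared core would keep the activity of compound 1, and this result shows that a halogen as such is not enough: with bromo in place of chloro, the change is an at least 4.1-fold higher number from compound 1 to compound 3 (0.61 log units; beyond the scatter), so this position separates one halogen from another as well as a halogen from methoxy. Compound 1 alone now carries a number at this position, and the step between compound 2 and compound 3 cannot be read, with the rest of the set resting on a single limit: the limit of > 10000 nM in this assay, at which 2 of the 3 values shown sit.

From the compounds shown here alone, how much activity is lost with bromo or with methoxy stays unknown, and so does any order between those two groups. The compounds shown also leave open whether fluoro, methyl or an amine on this carbon, or a shorter chain in place of the phenyl-bearing chain, would stay near compound 1 or fall to the same limit.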